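Adding a hydroxy to the side chain of compound 2

The source may report more compounds than this note shows. Statements on the series, on what has been measured and on what is new or still open speak of the compounds shown alone.

Among the compounds with values here, in an ADME assay (liver) for metabolic stability, with Liver microsome (Rattus norvegicus) as the target, using microsomes and NADPH, with a stated time of 30 min, at 37 degrees C, tested at 1 uM (a lower number here means slower removal, a higher number faster removal of the compound), compound 2 (`CC(C)(O)c1ccc(-c2ncc(S(=O)(=O)c3ccc(N)nc3)s2)c(Cl)c1`) gives 17 mL.min-1.g-1 as the only actual number so far. Compound 1 (`C[C@](O)(c1ccc(-c2ncc(S(=O)(=O)c3ccc(N)nc3)s2)c(Cl)c1)C(F)(F)F`) gives < 14 mL.min-1.g-1 as its result, and this is a limit of the assay and not a number. Within the data shown here, the one measured step is an at least 1.2-fold higher number from compound 1 to compound 2 (0.08 log units; that floor lies within the scatter) and comes with 1-hydroxy-1-methylethyl in place of 1-hydroxy-1-(trifluoromethyl)ethyl on an aromatic carbon.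

Compound 3 (`C[C@](O)(CO)c1ccc(-c2ncc(S(=O)(=O)c3ccc(N)nc3)s2)c(Cl)c1`) departs from compound 2 by hydroxy in place of hydrogen on a saturated chain carbon, two bonds along the chain from an aromatic carbon and an oxygen on a saturated carbon and so carries hydroxy in place of hydrogen on a saturated chain carbon, two bonds along the chain from an aromatic carbon and an oxygen on a saturated carbon. The same difference reads as 1-hydroxy-1-methylethyl to 1-hydroxy-1-(hydroxymethyl)ethyl. The step to compound 2 touches this same side chain but exchanges a different group, so an at least 1.2-fold higher number from compound 1 to compound 2 (0.08 log units; that floor lies within the scatter) is only a loose guide here and gives no firm direction. The expected move is a 1.2-fold lower number from compound 2 to compound 3 (0.08 log units; within the scatter) and would stay within the scatter of this assay as estimated here. For compound 3 the estimated value is 14 mL.min-1.g-1 with an expected range from 7 mL.min-1.g-1 to 26 mL.min-1.g-1 in this measurement, though the result could also come back as a limit.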

Compound 3, intrinsic clearance in microsomes: < 14 mL.min-1.g-1
Compound 3 was reported as a limit (the forecaster's own chance of this, stated with the estimate: 45%); the middle value lies on the limit itself.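

Hydroxy in place of hydrogen on this saturated chain carbon, two bonds along the chain from an aromatic carbon and an oxygen on a saturated carbon, gives an at least 1.2-fold lower number from compound 2 to compound 3 (0.08 log units; that floor lies within the scatter). In this assay, compound 3 gives < 14 mL.min-1.g-1, which is a limit of the assay and not a number. With this result, a side chain without trifluoromethyl also reaches the limit, so that group is not needed for a result of this kind among the compounds shown, but the step from compound 2 shows only a floor, not a confirmed drop, and the step between compound 1 and compound 3 cannot be read because both results sit at the same limit: the limit of < 14 mL.min-1.g-1 in this assay, at which 2 of the 3 values shown sit.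

From the compounds shown here alone, how far past the limit compound 3 truly lies stays open, so the real size of its step from compound 2 could be small or large. Also open, going by these compounds, is whether an amine or a carboxylic acid in place of this hydroxy, or a longer chain carrying the hydroxy, would give a number or a limit in this assay.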